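The source may hold more compounds than are shown below. What is called first, only, known or untested is meant among the compounds shown, and "the series" means these compounds.

Of the compounds shown here, three with a shared core have been measured in a functional assay on OVCAR-5 cells (Homo sapiens) for inhibition; on this read-out higher numbers stand for weaker inhibition of growth and lower numbers for stronger inhibition of growth. Compound 1 `COc1cc(/C=C/C(=O)c2cccc(-n3cc(-c4ccccc4)[nH]c3=O)c2)ccc1O` gives 2040 nM. Compound 2 `O=C(/C=C/c1cccc(O)c1)c1cccc(-n2cc(-c3ccc(Cl)cc3)[nH]c2=O)c1` gives 2190 nM. Compound 3 `COc1cc(/C=C/C(=O)c2cccc(-n3cc(-c4ccccc4)[nH]c3=O)c2)cc(OC)c1OC` gives 1880 nM, the lowest of the three numbers, yet it lies within the usual scatter of both compound 1 and compound 2, so the three cannot be told apart on growth inhibition.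

Compound 4 `COc1cc(/C=C/C(=O)c2cccc(-n3cc(-c4cc(OC)c(OC)c(OC)c4)[nH]c3=O)c2)cc(OC)c1OC` is not yet measured. It differs from compound 3 in one place: 3,4,5-trimethoxyphenyl in place of phenyl on an aromatic carbon. Within the data shown here, no step between measured compounds matches this change, so its effect can only be guessed. The three measured compounds sit close together. A step of modest size toward stronger inhibition is expected, with a real chance of none beyond the scatter.

Compound 4 is expected to give 1200 nM, between 400 nM and 4000 nM, in this assay; the step from compound 3 to compound 4 is estimated as a 1.6-fold lower number from compound 3 to compound 4 (0.19 log units; within the scatter).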

Compound 4, concentration for 50% growth inhibition: 4380 nM
Compound 4: the middle estimate sits 3.7-fold (0.56 log units) below what was measured; measured number outside the range, above it.
By their numbers in this assay, from the lowest: compounds 3, 1, 2 and 4 (each within the scatter of the next, the first and the last beyond it).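

In this assay, putting 3,4,5-trimethoxyphenyl in place of phenyl on this aromatic carbon gives a 2.3-fold higher number from compound 3 to compound 4 (0.37 log units; beyond the scatter) and so weakens growth inhibition. The earlier compounds shown here offered no step at this position, and this one shows that growth inhibition responds to the group placed there. Nothing measured here explains the loss.

A single step cannot show whether the added size or the added oxygen atoms matter. It also leaves open how a smaller group on this phenyl ring, such as one methoxy group or an amine, would behave.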